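Chloro-to-hydroxy swap on the fused core: expected step

A few compounds are considered here, and "the series" means these few. Any claim that something is new, unique, unknown or untested is made for them only; others in the source may bear on it.

Compound 1 `COc1cc(OC)c(-c2cc(=O)c3cc(Cl)ccc3o2)cc1OC` and compound 2 `COc1cc(OC)c(OC)cc1/C=C/C(=O)c1cc(Cl)ccc1O` share the trimethoxyphenyl part but differ in their cores; the difference between the two cores is not broken down here. In a functional assay on cells (Erythrocyte, Rattus norvegicus) for inhibition, read by hemolysis, with a stated time of 1 h (a lower number here means a stronger inhibitor, a higher number a weaker inhibitor), compound 1 gives 2.13 ug/mL, and compound 2 gives 2.23 ug/mL. Compound 3 `COc1cc(OC)c(OC)cc1/C=C/C(=O)c1cc(O)ccc1O` gives 2.1 ug/mL in this assay. The change from compound 2 to compound 3 is hydroxy in place of chloro on an aromatic carbon, and it made a 1.1-fold lower number from compound 2 to compound 3 (0.03 log units; within the scatter).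

Compound 4 `COc1cc(OC)c(-c2cc(=O)c3cc(O)ccc3o2)cc1OC` is not yet measured in this assay. It differs from compound 1 by hydroxy in place of chloro on an aromatic carbon. Within the data shown here, this is the same kind of change as the one from compound 2 to compound 3, though not the same: in compound 1 the exchanged carbon belongs to a six-membered aromatic ring of carbon only, part of a fused or bridged system of two rings, meta to a fused ring and para to a fused ring, whereas in compound 2 it is meta to a large group and para to a hydroxy group.

Among the measured compounds shown here, the only measured instance of this change sits within the scatter, so a small step is expected from compound 1 to compound 4 in this assay, about a 1.1-fold lower number from compound 1 to compound 4 (0.03 log units; within the scatter), resting on the step from compound 2 to compound 3 and on the near-identical values of compound 1 and compound 3. Compound 4 is therefore estimated at 2 ug/mL, expected to fall between 1.2 ug/mL and 3.4 ug/mL.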

Compound 4, half-maximal inhibitory concentration: 2.14 ug/mL
For compound 4 the middle estimate is 1.1-fold (0.03 log units) below the measured one; measured number inside the range.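

In this assay, hydroxy in place of chloro on an aromatic carbon of the core of compound 1 gives a 1.0-fold higher number from compound 1 to compound 4 (0.00 log units; within the scatter), so this swap leaves the number as flat on this core as on the core of compound 2. Across the two cores, the step therefore carries over without a difference that can be told from noise: the same change on two cores in this assay, a 1.1-fold lower number (0.03 log units; within the scatter) from compound 2 to compound 3 and a 1.0-fold higher number (0.00 log units; within the scatter) from compound 1 to compound 4, 1.1-fold (0.03 log units) apart, within the scatter of two such steps

Among these compounds, what this does not show is that a change with a real effect would carry over in the same way, since both steps lie within the scatter and the agreement is between two steps that are each indistinguishable from no change, on only two pairs of compounds in a single assay.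

The compounds shown leave open whether anything at this place on the ring moves the number at all, as only chloro and hydroxy appear there, and an amine, a carboxylic acid or a longer alkyl chain could behave differently. They also leave open how far the number depends on the trimethoxyphenyl part, which is common to all four compounds and is not varied here.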